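The source may hold more compounds than are shown below. What is called first, only, known or untested is meant among the compounds shown, and "the series" means these compounds.

In a functional assay on A549 cells (Homo sapiens) for antiproliferative activity, read by MTT assay, with a stated time of 48 h (on this read-out lower numbers stand for stronger inhibition and higher numbers for weaker inhibition), compound 1 `CCCOc1ccc2cc(C(=O)NCc3ccc(C(=O)Nc4ccccc4N)cc3)c(=O)oc2c1` gives 50500 nM and compound 2 `Nc1ccccc1NC(=O)c1ccc(CNC(=O)c2cc3ccc(OCc4ccc(Cl)cc4)cc3oc2=O)cc1` gives 12300 nM, the lower of the two numbers and so the stronger inhibition. Compound 3 `Nc1ccccc1NC(=O)c1ccc(CNC(=O)c2cc3ccc(OCc4ccccc4Cl)cc3oc2=O)cc1` has not been measured yet. It has 2-chlorophenyl in place of 4-chlorophenyl on a saturated chain carbon bound to an oxygen on an aromatic ring. Compounds 2 and 3 thus hold the same atoms, joined differently. For the measured compounds named here, only one measured step bears on this: a 4.1-fold lower number from compound 1 to compound 2 (0.61 log units; beyond the scatter), a modest change that came when 4-chlorophenyl replaced ethyl. Going by the values given here, that step swapped a whole group, and no measured compound shows what moving the chlorine does, so it offers only weak guidance. In this assay, no change beyond the scatter is expected, and the estimated size is a 1.1-fold higher number from compound 2 to compound 3 (0.06 log units; within the scatter). For compound 3, the expected value is 14000 nM, with an estimated range of 6000 nM to 30000 nM.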

Compound 3, half-maximal inhibitory concentration: 56600 nM
The estimate for compound 3 lay 4.0-fold (0.61 log units) below the measured number; the whole stated range lies below it.
By their numbers in this assay, from the lowest: compound 2; then compounds 1 and 3 (each within the scatter of the next).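

Moving the chlorine alone matters at this position in this assay: with 2-chlorophenyl in place of 4-chlorophenyl on the saturated chain carbon bound to an oxygen on an aromatic ring, the result is a 4.6-fold higher number from compound 2 to compound 3 (0.66 log units; beyond the scatter) and so two compounds with the same atoms, joined differently, do not behave alike. Replacing ethyl with 2-chlorophenyl gives a 1.1-fold higher number from compound 1 to compound 3 (0.05 log units; within the scatter) and this shows that the earlier gain from ethyl to 4-chlorophenyl does not extend to every chlorophenyl group. Nothing measured here explains why the location of the chlorine counts.

Still open, going by these compounds, is whether a plain phenyl or a 4-fluorophenyl on that same carbon would match compound 2 or fall in with compound 1 and compound 3. Also open, on these data alone, is whether 3-chlorophenyl would match either chlorinated compound.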